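Hydroxy Placement on the Aryl Ketone Ring

A few compounds are considered here, and "the series" means these few. Any claim that something is new, unique, unknown or untested is made for them only; others in the source may bear on it.

Compound 1 `Cn1c(/C=C/C(=O)c2cccc(O)c2)cc(Br)c1Br`, compound 2 `Cn1c(/C=C/C(=O)c2ccc(O)cc2O)cc(Br)c1Br` and compound 3 `Cn1c(/C=C/C(=O)c2ccc(O)cc2)cc(Br)c1Br` are measured; compound 4 `Cn1c(/C=C/C(=O)c2cc(O)ccc2O)cc(Br)c1Br` is not yet. In a functional assay on KB403 cells (Homo sapiens) for cytotoxicity, read by MTT assay, with stated times of 6 h and 48 h (on this read-out higher numbers stand for weaker inhibition and lower numbers for stronger inhibition), compound 1 gives only a limit of the assay, >= 100000 nM. Compound 3 likewise gives a limit, >= 100000 nM. Compound 2 gives 12000 nM. The step is an at least 8.3-fold lower number from compound 3 to compound 2 (0.92 log units; beyond the scatter), through (hydroxy in place of hydrogen on an aromatic carbon). The same kind of change separates compound 4 from compound 1: hydroxy in place of hydrogen on an aromatic carbon. The entering hydroxy sits meta to a hydroxy group in compound 2 but para to a hydroxy group in compound 4. How the cores of compound 1 and compound 3 differ is not broken down here. Among the compounds with values here, since the limit of >= 100000 nM in this assay, at which 2 of the 3 values shown sit, holds compound 1, the expected step is an at least 4.0-fold lower number from compound 1 to compound 4 (0.60 log units; beyond the scatter), resting on the single precedent an at least 8.3-fold lower number from compound 3 to compound 2 (0.92 log units; beyond the scatter). Compound 4 is estimated at 25000 nM, expected between 6000 nM and 100000 nM.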

Compound 4, half-maximal inhibitory concentration: >= 100000 nM
Compound 4 gave a limit, no number (the forecaster's own chance of this, stated with the estimate: 35%); middle value at least 4.0-fold (0.60 log units) from the limit.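

Compound 1 and compound 4 both give only a limit in this assay, so no step can be read between them: the limit of >= 100000 nM in this assay, at which 3 of the 4 values shown sit.

The compounds shown leave open whether the hydroxy entering compound 4 changes cytotoxicity at all.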